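Swapping methoxy for fluoro on a carbamate phenyl ring

The compounds below may be only part of what the source reports. "The series", "measured", "known", "first", "only" and "open" are said of these compounds alone.

Measured compounds:
- compound 1 `CCOc1cc(=O)n(CCCO)c2c1CC(C/C=C(\C)CCC=C(C)C)C(C)(C)C2` — 0.8%
- compound 2 `CC(C)=CCC/C(C)=C/CC1Cc2c(OCC=C(C)C)cc(=O)n(CCCO)c2CC1(C)C` — 15.9%
- compound 3 `COc1ccc(NC(=O)Oc2cc(=O)n(CCCO)c3c2CC(C/C=C(\C)CCC=C(C)C)C(C)(C)C3)cc1` — 0%

Three compounds sharing one core were tested in a functional assay on PANC-1 cells (Homo sapiens) for inhibition, read by MTT assay, with a stated time of 24 h, tested at 10 uM; a lower number here means less inhibition, a higher number more inhibition at the concentration tested (going by the name of the read-out). Compound 3 sits at the bottom of the three numbers: its gap to compound 1 is within the scatter, and only compound 2 stands clearly apart, as the step of a number 15.9 percentage points lower from compound 2 to compound 3 (beyond the scatter) shows. The step of a number 0.8 percentage points lower from compound 1 to compound 3 (within the scatter) shows that replacing ethyl with (4-methoxyphenyl)carbamoyl on the ring oxygen changed nothing beyond the scatter.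

Compound 4 `CC(C)=CCC/C(C)=C/CC1Cc2c(OC(=O)Nc3ccc(F)cc3)cc(=O)n(CCCO)c2CC1(C)C` is not yet measured. It differs from compound 3 in a single place: fluoro in place of methoxy on an aromatic carbon. Within the data shown here, none of the measured steps touches this phenyl ring; the only step that involves the carbamate at all is a number 0.8 percentage points lower from compound 1 to compound 3 (within the scatter), which was flat, and the one sizeable movement, a number 15.1 percentage points higher from compound 1 to compound 2 (beyond the scatter), concerns a different part of the molecule. There is therefore no measured ground to expect a change beyond the scatter in this assay, in either direction. Compound 4 is expected to stay close to compound 3, with an estimated step of a number 3 percentage points higher from compound 3 to compound 4 (within the scatter). The estimate for compound 4 is 3%, with a range from 0% to 12%.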

Compound 4, a percentage reported as inhibition, at one concentration (the size of the read-out at that concentration, not a potency): 6.2%
For compound 4 the middle estimate is 3.2 percentage points below the measured one, and the stated range covers the measured number.
By their numbers in this assay, from the lowest: compounds 3, 1, 4 and 2 (each within the scatter of the next, the first and the last beyond it).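

In this assay, among these compounds, the step of a number 6.2 percentage points higher from compound 3 to compound 4 (within the scatter) is the first direct test of this aromatic carbon, para to a large group, and it shows that fluoro in place of methoxy does not move the read-out beyond the scatter. The other two new steps place the (4-fluorophenyl)carbamoyl group among the ring-oxygen groups: a number 5.4 percentage points higher from compound 1 to compound 4 (within the scatter) against ethyl, and a number 9.7 percentage points lower from compound 2 to compound 4 (within the scatter) against 3-methylbut-2-en-1-yl, both small enough that compound 4 cannot be separated from either neighbour, although compound 3 stands clearly apart from compound 2. No supporting measurement bears on this result, so the small differences among these compounds remain without an explanation.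

The compounds shown leave open whether a chloro, a nitrile or a dimethylamino group on this same aromatic carbon would shift the number beyond the scatter, or whether a cyclohexyl ring could take the place of the phenyl ring of the carbamate. Every number here also comes from a single concentration, so none of them tells how potent any of these compounds is.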